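The source may hold more compounds than are shown below. What is called first, only, known or untested is meant among the compounds shown, and "the series" means these compounds.

Measured so far in a functional assay (aorta) with Rattus norvegicus as the target; on this read-out higher numbers stand for an effect only at larger amounts of compound and lower numbers for an effect already at smaller amounts:
- compound 1 `COc1ccc(-c2nc(CNC(=O)c3cccnc3)sc2-c2ccc(OC)cc2)cc1`: 8.2 uM
- compound 2 `COc1ccc(-c2nc(CNC(=O)CSC)sc2-c2ccc(OC)cc2)cc1`: 6 uM
- compound 3 `CNC(=O)NCc1nc(-c2ccc(OC)cc2)c(-c2ccc(OC)cc2)s1`: 15 uM

Compound 3 stands at 15 uM. The step of a 1.8-fold higher number from compound 1 to compound 3 (0.26 log units; within the scatter) stays inside the usual scatter, and only a 2.5-fold higher number from compound 2 to compound 3 (0.40 log units; beyond the scatter) goes beyond it, modestly.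

Compound 4 `CCOC(=O)/C(C#N)=C/c1nc(-c2ccc(OC)cc2)c(-c2ccc(OC)cc2)s1` keeps the shared core and changes in one place: 2-cyano-2-(ethoxycarbonyl)ethenyl in place of ((methylcarbamoyl)amino)methyl on an aromatic carbon.

Among the compounds with values here, no measured step replaces this whole group, so the evidence is only indirect. The three measured changes all swap what sits on a carbonyl carbon, and they are small: a 1.4-fold lower number from compound 1 to compound 2 (0.14 log units; within the scatter), a 1.8-fold higher number from compound 1 to compound 3 (0.26 log units; within the scatter) and a 2.5-fold higher number from compound 2 to compound 3 (0.40 log units; beyond the scatter). The change in compound 4 is larger than any of these, so the range must stay wide. Even so, the data point to no firm direction, and no step beyond the scatter is expected in this assay. The expected step is a 1.5-fold lower number from compound 3 to compound 4 (0.18 log units; within the scatter). Compound 4 is estimated at 10 uM, with an expected range of 3 uM to 35 uM.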

Compound 4, concentration for half-maximal effect: > 100 uM
Compound 4: no number, only a limit (the forecaster's own chance of this, stated with the estimate: 10%); at least 10-fold (1.00 log units) between middle value and limit.
By their numbers in this assay, from the lowest: compounds 2, 1 and 3 (each within the scatter of the next, the first and the last beyond it). At a limit, above all of these: compound 4.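

In this assay compound 4 gives only a limit, not a number: the limit of > 100 uM in this assay, at which 1 of the 4 values shown sits.

This position, on an aromatic carbon of the five-membered ring, proves sensitive to what it carries: the change to 2-cyano-2-(ethoxycarbonyl)ethenyl gives an at least 6.6-fold higher number from compound 3 to compound 4 (0.82 log units; beyond the scatter), an at least 16-fold higher number from compound 2 to compound 4 (1.22 log units; beyond the scatter) and an at least 12-fold higher number from compound 1 to compound 4 (1.08 log units; beyond the scatter). Within the data shown here, the earlier swaps on the carbonyl carbon moved the number far less, so only this wider change shows that the read-out can be lost almost entirely.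

The new group differs from the old ones in its nitrile, its ethyl ester and its double bond all at once, and the compounds shown cannot tell which of these matters. A simple amine on the methyl carbon, or a carboxylic acid in place of the ethyl ester, would help to separate these parts.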